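Enlarging the Amide Side Chain: Methyl to Isopropyl

The compounds below may be only part of what the source reports. "The series", "measured", "known", "first", "only" and "open" are said of these compounds alone.

Of the compounds shown here, two have so far been measured in a functional assay on the whole organism (strain Sprague-Dawley albino) for inhibition, with Rattus norvegicus as the target, in the maximal electroshock model; a higher number here means that more compound is needed for the effect, a lower number that less compound is needed. Compound 1 `CC(=O)NCC(=O)NCc1ccc(OCc2cccc(F)c2)cc1` gives 18 mg/kg, and compound 2 `CC(=O)N[C@H](C)C(=O)NCc1ccc(OCc2cccc(F)c2)cc1` gives 21 mg/kg. Among the compounds with values here, compound 2 stands highest of the two numbers, but its only neighbour, compound 1, lies within the scatter of it, so no order between them can be claimed. Within the data shown here, the single measured step, a 1.2-fold higher number from compound 1 to compound 2 (0.07 log units; within the scatter), bears directly on the present question, as it alters the same saturated chain carbon. Compound 3 `CC(=O)N[C@@H](C(=O)NCc1ccc(OCc2cccc(F)c2)cc1)C(C)C` has not yet been measured; it differs from compound 2 by isopropyl in place of methyl on a saturated chain carbon bound to an amide-type nitrogen and a carbonyl carbon. Because the earlier methyl-for-hydrogen change gave a 1.2-fold higher number from compound 1 to compound 2 (0.07 log units; within the scatter), the further enlargement to isopropyl is expected to yield a step of about a 1.2-fold higher number from compound 2 to compound 3 (0.08 log units; within the scatter), with no direction that clearly exceeds the scatter. Compound 3 is therefore estimated at 25 mg/kg, with a range from 12 mg/kg to 55 mg/kg.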

Compound 3, dose for half-maximal effect: > 30 mg/kg
Compound 3: a limit, no number (the forecaster's own chance of this, stated with the estimate: 10%); at least 1.2-fold (0.07 log units) between middle value and limit.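

For compound 3, this assay gives a limit and not a number: the limit of > 30 mg/kg in this assay, at which 1 of the 3 values shown sits.

Read as floors, the steps are an at least 1.4-fold higher number from compound 2 to compound 3 (0.15 log units; that floor lies within the scatter) and an at least 1.6-fold higher number from compound 1 to compound 3 (0.22 log units; that floor lies within the scatter), so isopropyl on this saturated chain carbon is not shown to separate from methyl or hydrogen beyond the scatter. What is new is that this change has no upper bound, whereas the methyl change, a 1.2-fold higher number from compound 1 to compound 2 (0.07 log units; within the scatter), is a closed step; the size of the isopropyl step may be close to its floor or far past it.

The compounds shown leave open how far past its limit compound 3 lies. They also leave open how an ethyl group or a methoxymethyl group on this same carbon would read in this assay.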